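The compounds below may be only part of what the source reports. "The series", "measured", "known", "first", "only" and "open" are said of these compounds alone.

Of the compounds shown here, two from this series have been tested in a functional assay on SW-620 cells (Homo sapiens) for antiproliferative activity, read by MTT assay, with a stated time of 72 h; a higher number here means a weaker inhibitor, a lower number a stronger inhibitor. Compound 1 `O=c1[nH]c(=O)n(CCC(CO)CO)cc1-c1ccco1` gives > 100000 nM, which is a limit of the assay rather than a number. Compound 2 `CC(=O)OCC(CCn1cc(C#Cc2ccc(Br)cc2)c(=O)n(C(=O)c2ccccc2)c1=O)COC(C)=O` likewise gives > 100000 nM, again a limit and not a measured value. Among the measured compounds shown here, both results therefore stand at the limit of > 100000 nM in this assay, at which 2 of the 2 values shown sit, so compound 2 cannot be placed above or below any other compound, and no step between measured compounds exists. Compound 3 `CCCCCC#Cc1cn(CCC(COC(C)=O)COC(C)=O)c(=O)n(C(=O)c2ccccc2)c1=O` differs from compound 2 in one place: pentyl in place of 4-bromophenyl on a triple-bonded carbon. For the measured compounds named here, with no measured step to guide the size of this change, the expected shift from compound 2 to compound 3 is a step that the limit leaves unreadable from compound 2 to compound 3, nothing beyond the usual scatter in either direction. Compound 3 is therefore expected to give about 150000 nM in this assay, within a range of 50000 nM to 500000 nM, most likely reported again only as a limit.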

Compound 3, half-maximal inhibitory concentration: 40700 nM
Compound 3: the middle estimate sits 3.7-fold (0.57 log units) above what was measured; the whole stated range lies above it.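

In this assay, compound 3 gives 40700 nM, a true measurement rather than a limit. Pentyl in place of 4-bromophenyl gives an at least 2.4-fold lower number from compound 2 to compound 3 (0.39 log units; beyond the scatter), which shows that the group on this triple-bonded carbon can change the result beyond the scatter, and that a ring is not needed there for a measurable value. The value of compound 2 is only a limit, so the real size of this step cannot be read and could be larger: the limit of > 100000 nM in this assay, at which 2 of the 3 values shown sit.

From the compounds shown here alone, it remains open whether a longer chain, such as octyl, or a pentyl chain ending in an amine would lower the number further. Going by these compounds, it is also open whether a smaller group, such as methyl, would keep the measurable activity seen with pentyl.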